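A few compounds are considered here, and "the series" means these few. Any claim that something is new, unique, unknown or untested is made for them only; others in the source may bear on it.

Compound 1 `CNc1ncnc2c1c(-c1ccoc1)cn2[C@@H]1O[C@H](CO)[C@@H](O)[C@H]1O`: > 20000 nM
Compound 2 `CNc1ncnc2c1c(-c1cccs1)cn2[C@@H]1O[C@H](CO)[C@@H](O)[C@H]1O`: > 20000 nM
Compound 3 `CNc1ncnc2c1c(-c1cc3ccccc3o1)cn2[C@@H]1O[C@H](CO)[C@@H](O)[C@H]1O`: > 20000 nM

Each of these values is a limit in a functional assay on CEM-DNR-bulk cells (Homo sapiens), read by MTT assay, with a stated time of 72 h (a higher number here means a weaker inhibitor, a lower number a stronger inhibitor), not a number. Compound 1 stands at the limit of > 20000 nM in this assay, at which 3 of the 3 values shown sit. Compound 4 `Cc1ncnc2c1c(-c1ccoc1)cn2[C@@H]1O[C@H](CO)[C@@H](O)[C@H]1O` carries methyl in place of methylamino on an aromatic carbon. Among the measured compounds shown here, no measured step covers this change. a step that the two limits leave unreadable from compound 1 to compound 2 and a step that the two limits leave unreadable from compound 1 to compound 3 have no readable size and alter a different group, as does a step that the two limits leave unreadable from compound 2 to compound 3. Any readable step in this assay is expected toward stronger inhibition because compound 1 gives > 20000 nM, a limit. The step expected is an at least 5.0-fold lower number from compound 1 to compound 4 (0.69 log units; beyond the scatter), with its size poorly fixed. Another limit reading remains possible. Compound 4 is estimated at 4000 nM, with an expected range of 300 nM to 20000 nM.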

Compound 4, half-maximal inhibitory concentration: > 20000 nM
Compound 4 ended at the assay's limit; the forecaster's own chance of this, stated with the estimate: 40%; at least 5.0-fold (0.69 log units) between middle value and limit.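

In this assay, among the compounds shown here, compound 4 gives > 20000 nM, a limit, so no step between compound 1 and compound 4 can be read: the limit of > 20000 nM in this assay, at which 4 of the 4 values shown sit. The compounds shown leave open how any of these groups on the shared core affects inhibition in this assay.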